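Benzylsulfonyl in place of (furan-2-yl)carbonyl on compound 3

The source may report more compounds than this note shows. Statements on the series, on what has been measured and on what is new or still open speak of the compounds shown alone.

In a functional assay on A-375 cells (Homo sapiens) for cytotoxicity, read by MTT assay (a lower number here means a stronger inhibitor, a higher number a weaker inhibitor), compound 1 `COc1ccc(/C=C/C(=O)c2ccc(OC)c3c2OC(C)(C)C=C3)cc1OCC=C(C)C` gives > 10000 nM as a limit only. Compound 2 `COc1ccc(/C=C/C(=O)c2ccc(OC)c3c2OC(C)(C)C=C3)cc1OC(=O)CCl` gives 450 nM in the same test. Compound 3 `COc1ccc(/C=C/C(=O)c2ccc(OC)c3c2OC(C)(C)C=C3)cc1OC(=O)c1ccco1` gives 680 nM and sits level with its chloromethyl partner, with a 1.5-fold higher number from compound 2 to compound 3 (0.18 log units; within the scatter) as the step.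

Compound 4 `COc1ccc(/C=C/C(=O)c2ccc(OC)c3c2OC(C)(C)C=C3)cc1OS(=O)(=O)Cc1ccccc1` differs from compound 3 by benzylsulfonyl in place of (furan-2-yl)carbonyl on an oxygen on an aromatic ring with benzylsulfonyl in place of (furan-2-yl)carbonyl on an oxygen on an aromatic ring. Going by the values given here, no measured step covers a sulfonyl group here. The large steps of an at least 22-fold lower number from compound 1 to compound 2 (1.34 log units; beyond the scatter) and an at least 14-fold lower number from compound 1 to compound 3 (1.16 log units; beyond the scatter) both remove 3-methylbut-2-en-1-yl, which compound 4 does not carry, so neither sets the expected size.

The expected step is a 1.8-fold higher number from compound 3 to compound 4 (0.25 log units; within the scatter) and no step beyond the scatter is expected. Compound 4 is estimated at 1200 nM within a range of 350 nM to 6000 nM in this assay for now.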

Compound 4, half-maximal inhibitory concentration: > 10000 nM
Compound 4 gave a limit, no number (the forecaster's own chance of this, stated with the estimate: 20%); middle value at least 8.3-fold (0.92 log units) away from the limit.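

In this assay, benzylsulfonyl on the oxygen on an aromatic ring gives an at least 14-fold higher number from compound 3 to compound 4 (1.16 log units; beyond the scatter) and an at least 22-fold higher number from compound 2 to compound 4 (1.34 log units; beyond the scatter). Among these four compounds, only the carbonyl-linked groups of compound 2 and compound 3 give readable numbers, so losing 3-methylbut-2-en-1-yl does not by itself secure activity. Compound 4 stands at a limit, shared with compound 1, and the step between them cannot be read: the limit of > 10000 nM in this assay, at which 2 of the 4 values shown sit.

Open, as far as these compounds go, is whether the sulfonyl link or the benzyl end accounts for the loss. Benzoyl or methylsulfonyl on this oxygen would separate the two.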